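The compounds below may be only part of what the source reports. "The series", "measured", "known", "first", "only" and "open" are said of these compounds alone.

Measured so far:
- compound 1, `COc1ccc(-c2nn3cc(-c4cccc(N)c4)nc3s2)cc1OC`: 16000 nM
- compound 2, `Nc1cccc(-c2cn3c(-c4ccccc4)csc3n2)c1`: 85000 nM
- compound 3, `COc1ccc(-c2nn3cc(-c4cccc(N)c4)nc3s2)cc1`: >= 250000 nM

In a functional assay on L1210 cells (Mus musculus) for inhibition, read by cell counting, with a stated time of 2 days (a higher number here means a weaker inhibitor, a lower number a stronger inhibitor), compound 1 gives 16000 nM. In this assay compound 2 gives 85000 nM. For compound 3 this assay reports only a limit, >= 250000 nM, not a number; this is the limit of >= 250000 nM in this assay, at which 1 of the 3 values shown sits.

Compound 3 and compound 1 differ in one place: methoxy in place of hydrogen on an aromatic carbon. That change gave an at least 15-fold lower number from compound 3 to compound 1 (1.19 log units; beyond the scatter), read against the limit of compound 3.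

Compound 4, `COc1ccc(-c2csc3nc(-c4cccc(N)c4)cn23)cc1`, has not yet been measured in this assay. It comes from compound 2 by the same kind of change: methoxy in place of hydrogen on an aromatic carbon. The two "place" descriptions do not agree word for word: in compound 1 the new methoxy sits ortho to a methoxy group and meta to a large group, whereas in compound 4 it sits para to a large group with no second methoxy nearby. The difference between the core of compound 2 and the core of compound 3 is not broken down here.

Because the measured step of an at least 15-fold lower number from compound 3 to compound 1 (1.19 log units; beyond the scatter) is only a lower bound and sits on a different core at a different place, a smaller step is expected from compound 2 to compound 4, estimated as a 2.1-fold lower number from compound 2 to compound 4 (0.33 log units; beyond the scatter). Compound 4 is therefore expected to give about 40000 nM in this assay, most likely between 10000 nM and 150000 nM.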

Compound 4, half-maximal inhibitory concentration: 19000 nM
Estimate against measurement, compound 4: 2.1-fold (0.32 log units) above; low and high end bracket the measured number.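

In this assay, putting methoxy in place of hydrogen on an aromatic carbon also lowers the number on the second core, with a 4.5-fold lower number from compound 2 to compound 4 (0.65 log units; beyond the scatter), so the direction of the step seen on the core of compound 1 holds in this pair as well. The size of the step does not carry over unchanged, as the two steps, read side by side, differ by more than their scatter: the same change on two cores in this assay, an at least 15-fold lower number (1.19 log units; beyond the scatter) from compound 3 to compound 1 and a 4.5-fold lower number (0.65 log units; beyond the scatter) from compound 2 to compound 4, at least 3.4-fold (0.54 log units) apart, beyond the scatter of two such steps Compound 3 is recorded only as a limit, >= 250000 nM, so the earlier step has no known upper size, and with the core and the place of the methoxy both differing between the two pairs, these data cannot show which of the two accounts for the gap, nor do two pairs make a general rule.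

As far as these compounds go, it remains open whether an ethoxy group, a hydroxyl group or a chlorine atom in the same place on the core of compound 2 would lower the number as methoxy does. From the compounds shown here alone, it is also open whether a second methoxy on that ring, of the kind compound 1 carries, would lower the number further on this core.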